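Shifting the Pyridine Nitrogen in Compound 1

A few compounds are considered here, and "the series" means these few. Any claim that something is new, unique, unknown or untested is made for them only; others in the source may bear on it.

Compound 1 `Cc1cn2c(/C=N/NC(=N)N)c(-c3ccncc3)nc2s1` gives the lower of the two numbers in a functional assay on colon cells (Homo sapiens) for antiproliferative activity (a lower number here means a stronger inhibitor of growth, a higher number a weaker inhibitor of growth), where compound 1 reaches 15800 nM. Within the data shown here, compound 2 `Cc1sc2nc(-c3ccncc3)c(/C=N/NC(=N)N)n2c1C` gives 35500 nM, and the only measured step, a 2.2-fold higher number from compound 1 to compound 2 (0.35 log units; beyond the scatter), concerns a methyl group rather than the pyridine. Compound 3 `Cc1cn2c(/C=N/NC(=N)N)c(-c3cccnc3)nc2s1` differs from compound 1 by pyridin-3-yl in place of pyridin-4-yl on an aromatic carbon. Among the measured compounds shown here, no measured step bears on this change, so the expectation rests on compound 1 alone. For compound 3 a step no larger than the scatter is expected, a 1.3-fold higher number from compound 1 to compound 3 (0.10 log units; within the scatter). Compound 3 is therefore estimated at 20000 nM, within 7000 nM to 60000 nM.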

Compound 3, concentration for 50% growth inhibition: 5620 nM
Compound 3: the middle estimate sits 3.6-fold (0.55 log units) above what was measured; the whole stated range lies above it.
By their numbers in this assay, from the lowest: compound 3; then compound 1; then compound 2.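

In this assay, the change from pyridin-4-yl to pyridin-3-yl gives a 2.8-fold lower number from compound 1 to compound 3 (0.45 log units; beyond the scatter) and lies beyond the scatter. This shows that the number responds to where the nitrogen sits in the pyridine, a feature that stayed fixed in the earlier methyl step. Compound 3 therefore has the lowest number of the three compounds. Nothing available explains this difference.

As far as these compounds go, how pyridin-2-yl or a plain phenyl would read at this aromatic carbon remains open. So does whether the added methyl would shift the number the same way alongside pyridin-3-yl.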